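A few compounds are considered here, and "the series" means these few. Any claim that something is new, unique, unknown or untested is made for them only; others in the source may bear on it.

The measured compounds are:
compound 1 `CCC/N=C1\S/C(=C\c2ccc(O)cc2)C(=O)N1c1ccccc1C`, which in a physicochemical assay for lipophilicity, read by HPLC, at pH 7.4 (on this read-out higher numbers stand for higher lipophilicity and lower numbers for lower lipophilicity), gives 3.5;
compound 2 `CCC/N=C1\S/C(=C\c2ccc(O)c(Cl)c2)C(=O)N1C1CCOCC1`, which in this assay gives 3.7;
compound 3 `CCC/N=C1\S/C(=C\c2ccc(O)c(C(C)C)c2)C(=O)N1c1ccccc1C`, which in this assay gives 4.3.

Compound 3 stands highest of the three numbers in this assay. Its nearest neighbour is compound 2, whose value is lower by a gap beyond the scatter, and compound 1 lies further still, also beyond the scatter. The one step that joins two of these compounds in a single place runs a number 0.80 log units higher from compound 1 to compound 3 (beyond the scatter), a modest rise when isopropyl replaces hydrogen on an aromatic carbon.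

Compound 4 `CCC/N=C1\S/C(=C\c2ccc(O)c(Cl)c2)C(=O)N1c1ccccc1C` has not yet been measured in this assay. It differs from compound 3 in one place: chloro in place of isopropyl on an aromatic carbon. Among the compounds with values here, compound 2 also carries a chloro group at that position, but it differs from compound 1 in two places, so those two values show only that compound 2 sits modestly above compound 1.

Within the data shown here, only the step from compound 1 to compound 3 bears directly on the change, and it sets the scale of what the isopropyl contributes. A chloro group of a single heavy atom entering in its place is expected to give back part of that rise, so the estimated step is a number 0.30 log units lower from compound 3 to compound 4 (within the scatter), a fall that may or may not clear the scatter. Compound 4 is therefore expected to give about 4 in this assay, with a likely range from 3.6 to 4.4.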

Compound 4, distribution coefficient: 3.8
Beside the measured number, compound 4's estimate is 0.20 log units above it; the range from low to high includes it.
By their numbers in this assay, from the lowest: compounds 1, 2 and 4 (each within the scatter of the next); then compound 3.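

In this assay, this position on an aromatic carbon, ortho to a hydroxy group, now gives a direct comparison of its two groups: the exchange of isopropyl for chloro reads a number 0.50 log units lower from compound 3 to compound 4 (beyond the scatter). Measured against hydrogen at the same place, chloro does not clear the scatter, with a number 0.30 log units higher from compound 1 to compound 4 (within the scatter), whereas isopropyl does, with a number 0.80 log units higher from compound 1 to compound 3 (beyond the scatter). With chloro held fixed, the exchange of oxan-4-yl for 2-methylphenyl on the amide-type nitrogen in a ring also stays within the scatter, at a number 0.10 log units higher from compound 2 to compound 4 (within the scatter), so this pair shows no separable change at that site.

The compounds shown leave open where a methoxy group, a trifluoromethyl group or a longer chain would fall at this position, and whether the isopropyl step would hold with oxan-4-yl on the nitrogen. No measurement at hand gives a reason for any of these steps.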